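The compounds below may be only part of what the source reports. "The series", "measured", "known", "first", "only" and "open" are said of these compounds alone.

Measured so far:
- compound 1, `CC1SC(c2cccc(C(=O)NCCCCc3ccccc3)c2)N(c2ccc(C3CC3)cc2)C1=O`: 3130 mL.min-1.g-1
- compound 2, `C#Cc1cccc(N2C(=O)CSC2c2cccc(C(=O)NCCCCc3ccccc3)c2)c1`: 1820 mL.min-1.g-1
- compound 3, `C#Cc1cc(C(=O)NCCCCc2ccccc2)cc(C2SCC(=O)N2c2ccccc2OC)c1`: 2200 mL.min-1.g-1

All three were run in an ADME assay on microsomes from liver (Rattus norvegicus) for metabolic stability, read by LC-MS, using NADPH, with a stated time of 10 min, tested at 0.1 uM; on this read-out higher numbers stand for fast clearance and lower numbers for slow clearance. In this assay compound 1 gives the highest of the three numbers, yet its gap to compound 3 and its gap to compound 2 both stay within the scatter of repeated measurements, so no order among the three can be read from these values; the series as measured sits at uniformly fast clearance.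

Compound 4, `O=C(NCCCCc1ccccc1)c1cccc(C2SCC(=O)N2c2ccc(C3CC3)cc2)c1`, is not yet measured in this assay. It differs from compound 1 at a single point on the shared core: hydrogen in place of methyl on a saturated ring carbon, on the five-membered non-aromatic ring with 1 nitrogen and 1 sulfur. The groups on the ring nitrogen and on the amide side of the core are kept. Among the compounds with values here, no step between measured compounds bears on this change, so nothing in the data shows what the loss of the methyl does to the read-out.

The expectation for compound 4 is a number close to that of compound 1, with the step of a 1.2-fold lower number from compound 1 to compound 4 (0.06 log units; within the scatter) estimated as none beyond the scatter, in either direction. Compound 4 is estimated at 2700 mL.min-1.g-1 in this assay, within 1400 mL.min-1.g-1 to 5200 mL.min-1.g-1.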

Compound 4, intrinsic clearance in microsomes: 2280 mL.min-1.g-1
Compound 4: the middle estimate sits 1.2-fold (0.07 log units) above what was measured; the measured number falls inside the stated range.
By their numbers in this assay, from the lowest: compounds 2, 3, 4 and 1 (each within the scatter of the next).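

In this assay, within the data shown here, the methyl on the saturated ring carbon next to the ring sulfur gives way to hydrogen with a 1.4-fold lower number from compound 1 to compound 4 (0.14 log units; within the scatter) as the result, the first single-place reading at this position, and it shows no effect that can be told from the scatter. On the amide-type nitrogen in a ring, 4-cyclopropylphenyl in place of 3-ethynylphenyl gives a 1.3-fold higher number from compound 2 to compound 4 (0.10 log units; within the scatter) as its step, so that place also shows no separation from the scatter. No available measurement bears on why these two changes leave the read-out unresolved.

Going by these compounds, whether a larger group on this ring carbon, such as ethyl or hydroxymethyl, would give a step beyond the scatter stays open. Also open, on these data alone, is whether a change on the amide side of the core, such as a shorter chain or an added amine, would do so.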